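A 4-methylphenyl group on the sulfur

The source may hold more compounds than are shown below. What is called first, only, known or untested is meant among the compounds shown, and "the series" means these compounds.

Compound 2 `Nc1ccccc1NC(=O)c1ccc(CSc2cccc(F)c2)cc1` stands at 22.5% in a functional assay on HeLa cells (Homo sapiens) for inhibition, read by CCK-8 assay, with a stated time of 72 h, tested at 2 uM (on this read-out higher numbers stand for more inhibition of growth at the one concentration tested and lower numbers for less inhibition of growth), and compound 1 `CCc1ccc(SCc2ccc(C(=O)Nc3ccccc3N)cc2)cc1` stands at 30.8% on the same read-out, so the two cannot be told apart. The change leading to compound 3 `Cc1ccc(SCc2ccc(C(=O)Nc3ccccc3N)cc2)cc1` is 4-methylphenyl in place of 3-fluorophenyl on a sulfur and nothing else. Among the measured compounds shown here, one measured step bears on it (a number 8.3 percentage points lower from compound 1 to compound 2 (within the scatter)), and that step put 3-fluorophenyl in place of 4-ethylphenyl on the same sulfur. It lies within the scatter, so no step beyond the scatter is expected here. Compound 1 at 30.8% is the closer model for compound 3, as both carry a 4-substituted phenyl. The estimated move is small and upward (a number 4.5 percentage points higher from compound 2 to compound 3 (within the scatter)) and is expected to stay inside the scatter. For compound 3 the expected value is 27% with an estimated range of 15% to 39% in this assay overall.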

Compound 3, percent growth inhibition at one concentration: 33.8%
Compound 3: the middle estimate sits 6.8 percentage points below what was measured; the range from low to high includes it.
By their numbers in this assay, from the lowest: compounds 2, 1 and 3 (each within the scatter of the next, the first and the last beyond it).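

In this assay, among the compounds shown here, the change on the sulfur now gives a step beyond the scatter, a number 11.3 percentage points higher from compound 2 to compound 3 (beyond the scatter), the only one of the three steps at this position to pass it, and only modestly. Replacing the ethyl of the 4-ethylphenyl by the methyl of the 4-methylphenyl, a number 3 percentage points higher from compound 1 to compound 3 (within the scatter), stays within the scatter, so compound 1 and compound 3 cannot be told apart. Nothing measured here bears on why the 3-fluorophenyl and 4-methylphenyl groups part in this way.

The compounds shown leave open whether the step follows from losing the fluorine or from gaining the methyl. They also leave open how an amine or a carboxylic acid in place of that methyl, or a chain longer than ethyl, would read.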